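From a methoxyphenyl arm to a bromofluorophenyl arm

The compounds below may be only part of what the source reports. "The series", "measured", "known", "first", "only" and "open" are said of these compounds alone.

Compound 3 `C=CCn1c(=O)/c(=C\c2ccccc2OC)[nH]c(=O)/c1=C\c1ccccc1OC` gives 5100 nM in a functional assay on U-937 cells (Homo sapiens) for cytotoxicity, read by CCK-8 assay, with a stated time of 72 h (on this read-out higher numbers stand for weaker inhibition and lower numbers for stronger inhibition), the highest of the two numbers in hand; compound 2 `C=CCn1c(=O)/c(=C\c2cc(Br)ccc2F)[nH]c(=O)/c1=C\c1ccccc1OC` sits nearest with 4700 nM, and compound 1 `C=CCn1c(=O)/c(=C\c2ccc(Cl)c(Cl)c2)[nH]c(=O)/c1=C\c1ccccc1OC` is recorded only as "not active" (no number reported). Compound 4 `C=CCn1c(=O)/c(=C\c2ccc(F)c(Br)c2)[nH]c(=O)/c1=C\c1ccccc1OC` carries 3-bromo-4-fluorophenyl in place of 2-methoxyphenyl on a double-bonded chain carbon bound to an aromatic carbon. For the measured compounds named here, the one measured step, a 1.1-fold higher number from compound 2 to compound 3 (0.04 log units; within the scatter), traded 5-bromo-2-fluorophenyl for the same methoxyphenyl and stayed within the scatter, so the present exchange offers no ground for expecting a move beyond it. Compound 1, whose differing ring yielded no number at all, is a reminder that a ring of this kind may also fall out of range. Compound 4 is therefore expected to give about 6000 nM (2500 nM to 15000 nM), an expected step of a 1.2-fold higher number from compound 3 to compound 4 (0.07 log units; within the scatter).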

Compound 4, half-maximal inhibitory concentration: "not active" (no number reported)
Nothing numeric was reported for compound 4; no gap can be computed for the estimate.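

In this assay, for the compounds shown here, compound 4 gives "not active" (no number reported) and so no step from compound 3 can be read. The compounds shown leave open what separates compound 1 and compound 4 from compound 2 and compound 3. No measurement at hand bears on this result.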